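The source may report more compounds than this note shows. Statements on the series, on what has been measured and on what is new or still open speak of the compounds shown alone.

Measured so far:
compound 1 (`CC1(/C=C/c2ccccc2C(F)(F)F)C=CC(=O)O1`) gives 17900 nM
compound 2 (`COc1ccc(/C=C/C2(C)C=CC(=O)O2)c(OC)c1OC`) gives 90000 nM

In a functional assay on PC-3 cells (Homo sapiens) for inhibition, read by sulforhodamine B assay, with a stated time of 48 h (on this read-out higher numbers stand for weaker inhibition of growth and lower numbers for stronger inhibition of growth), compound 1 stands lowest of the two, with compound 2 higher by more than the usual scatter. Compound 3 (`COc1ccccc1/C=C/C1(C)C=CC(=O)O1`) departs from compound 1 in one place: methoxy in place of trifluoromethyl on an aromatic carbon. Within the data shown here, no measured pair differs in one place, so the guide is thin. Compound 2, which also carries methoxy, gives 90000 nM in this assay and points to a higher number, meaning weaker inhibition of growth. The estimated move is a 2.2-fold higher number from compound 1 to compound 3 (0.35 log units; beyond the scatter) and is expected to lie near the edge of the scatter. For compound 3 the estimated value is 40000 nM with an expected range from 15000 nM to 90000 nM in this series.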

Compound 3, concentration for total growth inhibition: 34200 nM
Compound 3: middle estimate off by 1.2-fold (0.07 log units), on the high side, and the stated range covers the measured number.
By their numbers in this assay, from the lowest: compounds 1 and 3 (each within the scatter of the next); then compound 2.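

In this assay methoxy in place of trifluoromethyl on an aromatic carbon gives a 1.9-fold higher number from compound 1 to compound 3 (0.28 log units; within the scatter) and this is the only single-place step shown. At this carbon, ortho to a group of 9 heavy atoms, the exchange leaves the read-out within the usual scatter, even though one hydrogen-bond acceptor enters with methoxy. No measured evidence bears on this result. As far as these compounds go, an amine or a carboxylic acid at this carbon remains open. So does whether methoxy on another aromatic carbon would give the same outcome.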